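The compounds below may be only part of what the source reports. "The series", "measured", "known", "first", "only" and "open" are said of these compounds alone.

The compounds here share one core, on which a saturated chain carbon bound to an oxygen on an unsaturated carbon carries the group that varies. For the measured compounds named here, compound 2 `CCC1(Cc2ccccc2)OS(=O)(=O)C=C1OCC=C(C)C` is the point of reference: in an ADME assay on HEL cells (Homo sapiens) for cytotoxicity, with a stated time of 3 days (a higher number here means that more compound is tolerated, a lower number that less compound is tolerated), compound 2 gives 400000 nM, and this is the only plain number among the values shown. Compound 1 `CCC1(Cc2ccccc2)OS(=O)(=O)C=C1OCc1ccc([N+](=O)[O-])cc1` is the other measured member. In this assay compound 1 gives >= 80000 nM, which is a limit of the assay rather than a number. Accordingly the step that the limit leaves unreadable from compound 1 to compound 2 cannot be given a size because the limit of >= 80000 nM in this assay, at which 1 of the 2 values shown sits, hides where compound 1 truly lies. Compound 3 `CCC1(Cc2ccccc2)OS(=O)(=O)C=C1OCc1ccccc1` has not yet been measured. Its difference from compound 2 is phenyl in place of 2-methylprop-1-en-1-yl on a saturated chain carbon bound to an oxygen on an unsaturated carbon. Going by the values given here, only the step from compound 1 to compound 2 bears on this change, and since its size is unreadable, no direction can be taken from it. The step of a 1.3-fold lower number from compound 2 to compound 3 (0.12 log units; within the scatter) is therefore expected to lie within the usual scatter. For compound 3 in this assay the estimate is 300000 nM, with a range from 100000 nM to 700000 nM.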

Compound 3, minimum cytotoxic concentration: >= 50000 nM
Compound 3 was reported as a limit (the forecaster's own chance of this, stated with the estimate: 25%); the middle value does not contradict the limit.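

In this assay compound 3 gives >= 50000 nM, which is a limit of the assay and not a number. For the compounds shown here, no new step can therefore be read, either from compound 2 to compound 3 or from compound 1 to compound 3. The compounds shown leave open whether phenyl in place of 2-methylprop-1-en-1-yl, or hydrogen in place of nitro, changes the number in this assay, and in which direction.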